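Compound 4 in a Lung Stability Series

The source may hold more compounds than are shown below. What is called first, only, known or untested is meant among the compounds shown, and "the series" means these compounds.

Compound 1 `Cc1csc2cc([C@H](C)Nc3ncnc(N)c3C#N)c(-c3cccc(CN(C)CCCCN(C)Cc4ccccc4)c3)c(=O)n12` was tested in an ADME assay on the whole organism (lung, Rattus norvegicus) for metabolic stability, read by LC-MS, with a stated time of 24 h (a lower number here means that less of the compound is left, a higher number that more of the compound is left), and gives 7.4%. Compound 3 `Cc1csc2cc([C@H](C)Nc3ncnc(N)c3C#N)c(-c3cccc(CN4CCC(CN(C)Cc5ccccn5)CC4)c3)c(=O)n12` gives 5.2% and compound 2 `Cc1csc2cc([C@H](C)Nc3ncnc(N)c3C#N)c(Cc3cccc(CN4CCC4)c3)c(=O)n12` gives 0%; both numbers lie within the usual scatter of that of compound 1, so no order among the three can be read from this assay. Compound 4 `Cc1csc2cc([C@H](C)Nc3ncnc(N)c3C#N)c(-c3cccc(CN(C)CCCN4C[C@@H](C)O[C@@H](C)C4)c3)c(=O)n12` differs from compound 1 by 2,6-dimethylmorpholin-4-yl in place of (benzyl(methyl)amino)methyl on a saturated chain carbon, three bonds along the chain from an amine nitrogen. Among the measured compounds shown here, no step between measured compounds in this assay is at hand, and all three numbers sit low, so the step from compound 1 to compound 4 is expected to stay within the scatter, with a number 2.4 percentage points lower from compound 1 to compound 4 (within the scatter). Compound 4 is therefore estimated to give 5% in this assay, with a range from 0% to 15%.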

Compound 4, percent of the compound remaining: 0.8%
For compound 4 the middle estimate is 4.2 percentage points above the measured one; measured number inside the range.
By their numbers in this assay, from the lowest: compounds 2, 4, 3 and 1 (each within the scatter of the next).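

Among the compounds shown here, replacing (benzyl(methyl)amino)methyl with 2,6-dimethylmorpholin-4-yl on a saturated chain carbon, three bonds along the chain from an amine nitrogen, gives a number 6.6 percentage points lower from compound 1 to compound 4 (within the scatter) in this assay and is the first step that can be read at this position. At this position, a group with a six-membered aromatic ring of carbon only and one with a non-aromatic ring with 2 hetero atoms therefore cannot be told apart in this measurement. No measurement shown accounts for this result.

Going by these compounds, whether any group at this carbon can bring the number beyond the scatter stays open. A dimethylamino group, a carboxylic acid or a longer chain there would test this.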